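Allyl ester to piperidine amide on a brine shrimp scaffold

The compounds below may be only part of what the source reports. "The series", "measured", "known", "first", "only" and "open" are said of these compounds alone.

Measured compounds:
compound 1, `C=CCOC(=O)/C=C1/[C@H](C)O[C@@H](O[Si](C)(C)C(C)(C)C)C[C@@H]1OC`, 0.002 ug/mL
compound 2, `CO/N=C/C=C1\[C@H](C)O[C@@H](O[Si](C)(C)C(C)(C)C)C[C@@H]1OC`, 0.01 ug/mL

In a functional assay on the whole organism for inhibition, with Artemia salina as the target (a higher number here means a weaker inhibitor of growth, a lower number a stronger inhibitor of growth), compound 1 gives 0.002 ug/mL, the lowest of the two numbers in hand. Its nearest neighbour, compound 2, gives 0.01 ug/mL, a gap beyond the scatter; the two structures differ at more than one place, so only their two values are compared here. Compound 3, `CO[C@H]1C[C@H](O[Si](C)(C)C(C)(C)C)O[C@@H](C)/C1=C/C(=O)N1CCCCC1`, is not yet measured. It differs from compound 1 by piperidin-1-yl in place of allyloxy on a carbonyl carbon. Among the measured compounds shown here, no step between measured compounds is available for this kind of change, so the size of the step rests on expectation alone. Compound 3 is expected to sit somewhat higher than compound 1, with the step a number 2.3 two-fold dilutions higher from compound 1 to compound 3 (beyond the scatter) estimated as modest and in the direction of weaker growth inhibition. For compound 3 the estimate in this assay is 0.01 ug/mL, with a range from 0.002 ug/mL to 0.05 ug/mL.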

Compound 3, minimum inhibitory concentration: 0.002 ug/mL
Beside the measured number, compound 3's estimate is 2.3 two-fold dilutions above it, within the range that was stated.
By their numbers in this assay, from the lowest: compounds 1 and 3 (each within the scatter of the next); then compound 2.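

Putting piperidin-1-yl in place of allyloxy on a carbonyl carbon gives, in this assay and with the rest of the structure unchanged, no change at the digits printed from compound 1 to compound 3 (within the scatter) and so shows that this position accepts the change. Neither the allyloxy group nor its double bond is needed to keep this read-out, and a six-membered ring with a nitrogen attached to the carbonyl carbon serves equally well. Nothing at hand gives a measured reason for this tolerance.

As far as these compounds go, what remains open is whether this holds for a carboxylic acid, a small open-chain amine such as dimethylamino, or morpholin-4-yl on the same carbonyl carbon. Also open, from the compounds shown here alone, is whether piperidin-1-yl would be accepted equally well on a core carrying a different group in place of the silyl ether.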